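The source may report more compounds than this note shows. Statements on the series, on what has been measured and on what is new or still open speak of the compounds shown alone.

Measured compounds in a functional assay (trachea) with Rattus norvegicus as the target; on this read-out lower numbers stand for lower potency and higher numbers for higher potency (the scale is a negative logarithm): compound 1 `CC1(C)C=C(n2ccccc2=O)c2cc(C(=O)c3ccc([N+](=O)[O-])cc3)ccc2O1` gives 6.09; compound 2 `CC1(C)C=C(n2ccccc2=O)c2cc(C(=O)c3ccccc3F)ccc2O1` gives 6.34; compound 3 `CC1(C)C=C(n2ccccc2=O)c2cc(C(=O)c3c(F)cccc3F)ccc2O1` gives 5.99.

Compound 2 has the highest of the three numbers, although compound 1 lies within the scatter of it, with a number 0.25 log units higher from compound 1 to compound 2 (within the scatter), while compound 3 sits further off, with a number 0.35 log units lower from compound 2 to compound 3 (beyond the scatter). Compound 4 `CC1(C)C=C(n2ccccc2=O)c2cc(Br)ccc2O1` has not yet been tested. It differs from compound 2 by bromo in place of (2-fluorophenyl)carbonyl on an aromatic carbon. The measured steps all swap one aromatic group for another on the carbonyl carbon and move the numbers only modestly, so none bears directly on removing the whole ketone; the direction is therefore uncertain and a small drop is a guess. Compound 4 is expected to give 5.8, between 5 and 6.6. This estimate means an expected step of a number 0.54 log units lower from compound 2 to compound 4 (beyond the scatter).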

Compound 4, logarithm of the reciprocal of the active concentration, log(1/C): 7.53
The estimate for compound 4 lay 1.73 log units below the measured number, and the stated range ends below it.
By their numbers in this assay, from the lowest: compounds 3, 1 and 2 (each within the scatter of the next, the first and the last beyond it); then compound 4.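

Replacing the whole (2-fluorophenyl)carbonyl with a single bromo gives a number 1.19 log units higher from compound 2 to compound 4 (beyond the scatter) in this assay. The earlier compounds shown here only exchanged one aromatic group for another on the carbonyl carbon, whereas this result shows that the shared core keeps its potency in this assay without any aromatic ketone at this position, and that a single atom there can give a higher number. Nothing available explains this rise. As far as these compounds go, it remains open whether bromo itself matters or only the loss of the ketone. A chloro, a nitrile or a plain hydrogen at this position could separate the two.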